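Swapping the indole acid for a nitrogen-bearing bicycle

The compounds below may be only part of what the source reports. "The series", "measured", "known", "first", "only" and "open" are said of these compounds alone.

Compound 1 `Cn1c(=O)c(S(=O)(=O)c2ccc(F)cc2F)cc2cnc(Nc3ccc4[nH]c(C(=O)O)cc4c3)nc21` is measured in a functional assay on K562 cells (Homo sapiens) for inhibition, read by trypan blue exclusion, with a stated time of 72 h (a lower number here means a stronger inhibitor, a higher number a weaker inhibitor), where compound 1 gives 10000 nM, the highest of the three numbers. Going by the values given here, compound 2 `Cn1c(=O)c(S(=O)(=O)c2ccc(O)cc2)cc2cnc(Nc3ccc4[nH]ccc4c3)nc21` gives 100 nM and compound 3 `Cn1c(=O)c(C(=O)Nc2ccc(F)cc2F)cc2cnc(Nc3ccc4[nH]ccc4c3)nc21` gives 5000 nM; the one measured step, a 50-fold higher number from compound 2 to compound 3 (1.70 log units; beyond the scatter), changes a different part of the molecule and so says little about the change examined here. Compound 4 `Cn1c(=O)c(S(=O)(=O)c2ccc(F)cc2F)cc2cnc(Nc3cnc4[nH]ccc4c3)nc21` differs from compound 1 in this way: a group of 9 heavy atoms (7 carbon, 2 nitrogen; one five-membered aromatic ring with 1 hetero atom, one six-membered aromatic ring with 1 hetero atom) in place of a group of 12 heavy atoms (9 carbon, 1 nitrogen, 2 oxygen; one five-membered aromatic ring with 1 hetero atom, one six-membered aromatic ring of carbon only), on a nitrogen on an aromatic ring. Compound 1 and compound 2 differ in two places at once, so their values show only that a plain indole without the acid can sit on a potent compound. Among the compounds with values here, with no directly comparable step, compound 4 is expected to give 2000 nM, between 300 nM and 10000 nM, a step of a 5.0-fold lower number from compound 1 to compound 4 (0.70 log units; beyond the scatter) that is judged uncertain.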

Compound 4, half-maximal inhibitory concentration: 750 nM
For compound 4 the middle estimate is 2.7-fold (0.43 log units) above the measured one; measured number inside the range.
By their numbers in this assay, from the lowest: compound 2; then compound 4; then compounds 3 and 1 (each within the scatter of the next).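

In this assay the step of a 13-fold lower number from compound 1 to compound 4 (1.12 log units; beyond the scatter) shows that the 2-carboxy-1H-indol-5-yl group is not needed on this nitrogen, and that replacing it gives a clear gain with the rest of compound 1 held fixed. Going by these compounds alone, this is the first direct reading of a change at this position. No measurement shown here explains the gain.

The step removes the carboxylic acid and places a nitrogen in the six-membered ring at once, so the two changes cannot be told apart. Going by these compounds, whether an amine or a methoxy group on the entering group would keep this gain stays open.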